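A few compounds are considered here, and "the series" means these few. Any claim that something is new, unique, unknown or untested is made for them only; others in the source may bear on it.

Of the compounds shown here, three built on one shared core have been tested in a functional assay on QGY7701 cells (Homo sapiens) for cytotoxicity, read by MTT assay, with a stated time of 24 h; a lower number here means a stronger inhibitor, a higher number a weaker inhibitor. Compound 1 `C=CC1=C(C(=O)NCc2ccccc2)C(c2ccc(OC)c(OC)c2)OC1` gives in this assay > 100000 nM, which is a limit of the assay and not a number. Compound 2 `C=CC1=C(C(=O)NCc2ccc(Cl)cc2)C(c2ccc(OC)cc2)OC1` gives in this assay > 100000 nM, again a limit rather than a measured number. Compound 3 `C=CC1=C(C(=O)NCCCCC)C(c2ccc(OC)cc2)OC1` gives in this assay > 100000 nM, also a limit. Compound 2 thus stands at the same limit as everything else shown (the limit of > 100000 nM in this assay, at which 3 of the 3 values shown sit), so it cannot be ranked against the other two. The step that the two limits leave unreadable from compound 2 to compound 3 cannot be read; both of its ends are limits.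

Compound 4 `C=CC1=C(C(=O)NCc2ccc(Cl)cc2)C(c2ccc(OC)c(OC)c2)OC1` has not been measured. It differs from compound 2 by methoxy in place of hydrogen on an aromatic carbon. Going by the values given here, no measured step covers this change: compound 1 already carries the entering methoxy and compound 2 already carries the 4-chlorophenyl, and both sit at the limit. Among the compounds with values here, nothing among the measured compounds points toward a gain in potency, so compound 4 is expected to stay at the limit, with the step that the limit leaves unreadable from compound 2 to compound 4 estimated as none beyond the scatter. Compound 4 is estimated at 150000 nM in this assay, within a range of 50000 nM to 1000000 nM.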

Compound 4, half-maximal inhibitory concentration: > 100000 nM
Compound 4 ended at the assay's limit (the forecaster's own chance of this, stated with the estimate: 85%); the middle value does not contradict the limit.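

Compound 4 joins compound 1 and compound 2 at a limit of the assay rather than a number, so neither its step from compound 2 nor its step from compound 1 can be read: the limit of > 100000 nM in this assay, at which 4 of the 4 values shown sit.

The compounds shown leave open how far apart they truly lie, and which change to the shared core would give a readable value in this assay at all.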